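The compounds below may be only part of what the source reports. "The series", "measured", "known", "first", "only" and "open" are said of these compounds alone.

Working notes on the series.

Going by the values given here, compound 2 `COc1ccc2c(c1)[n+]([O-])c(NCCN(C)C)n[n+]2[O-]` gives the higher of the two numbers so far in a physicochemical assay for solubility, in the presence of a further agent that is not named here (a higher number here means a more soluble compound, a lower number a less soluble compound), where compound 2 gives 46000000 nM. Among the compounds with values here, its nearest neighbour is compound 1 `CN(C)CCNc1n[n+]([O-])c2ccc(C(C)(C)C)cc2[n+]1[O-]`, and in this assay compound 1 gives 38000000 nM; the only measured step, a 1.2-fold higher number from compound 1 to compound 2 (0.08 log units; within the scatter), is within the scatter and so does not separate the two.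

Compound 3 `COCCOc1ccc2c(c1)[n+]([O-])c(NCCN(C)C)n[n+]2[O-]` differs from compound 2 by methoxymethyl in place of hydrogen on a saturated chain carbon bound to an oxygen on an aromatic ring. Within the data shown here, no measured step touches this kind of change; the one step on hand, a 1.2-fold higher number from compound 1 to compound 2 (0.08 log units; within the scatter), concerns a different part of the molecule and was itself within the scatter, so it gives no direction for the new step. The expectation for this assay is therefore no step beyond the scatter, with the estimate resting on the value of compound 2, 46000000 nM.

Compound 3 is accordingly expected at 40000000 nM, within 20000000 nM to 80000000 nM, which amounts to an estimated step of a 1.2-fold lower number from compound 2 to compound 3 (0.06 log units; within the scatter).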

Compound 3, solubility: 43000000 nM
Estimate against measurement, compound 3: 1.1-fold (0.03 log units) below; the measured number falls inside the stated range.
By their numbers in this assay, from the lowest: compounds 1, 3 and 2 (each within the scatter of the next).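

In this assay, going by these compounds alone, the methoxy of compound 2 can be lengthened to 2-methoxyethoxy with only a small change, a 1.1-fold lower number from compound 2 to compound 3 (0.03 log units; within the scatter), and this is the first reading for a change within that chain. The direct exchange of tert-butyl for 2-methoxyethoxy on the aromatic carbon, a 1.1-fold higher number from compound 1 to compound 3 (0.05 log units; within the scatter), also stays within the scatter, so tert-butyl, methoxy and 2-methoxyethoxy on that carbon are not separated by this read-out. Nothing available bears on why these numbers stay so close.

On these data alone, whether an amine or a carboxylic acid on the same aromatic carbon would give a step beyond the scatter remains open. Also open, as far as these compounds go, is what a longer chain in place of the side chain shared by all three compounds would do to the number.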